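This account rests on a few compounds, and the source may have more. Where it says the series, first, only, none or still open, it means among the compounds named here.

Measured in a functional assay on HCC827 cells (Homo sapiens) for inhibition, read by fluorescence, with a stated time of 72 h; a higher number here means a weaker inhibitor of growth, a lower number a stronger inhibitor of growth:
- Compound 1 `CC(C)CCn1cnc2c(Nc3ccc(Cl)cc3)nc(N[C@H]3CC[C@H](N)CC3)nc21`: 10200 nM
- Compound 2 `CCCCn1cnc2c(NCc3cccc(Cl)c3)nc(N[C@H]3CC[C@H](N)CC3)nc21`: 10600 nM

With only these two results, compound 2 at 10600 nM lies within the usual scatter of compound 1 at 10200 nM, so the two cannot be ranked. Compound 3 `CCCCn1cnc2c(Nc3ccc(Cl)cc3)nc(N[C@H]3CC[C@H](N)CC3)nc21` keeps the rest of compound 2 and alters one group: 4-chlorophenyl in place of 3-chlorobenzyl on a nitrogen on an aromatic ring. Put simply, this is 4-chlorophenyl in place of 3-chlorobenzyl on a nitrogen on an aromatic ring. Among the measured compounds shown here, no measured pair isolates this change, so the expectation rests on thin evidence. Compound 1 also carries the 4-chlorophenyl group and gives 10200 nM, so no step beyond the scatter is expected in this assay. The expected change is a 1.2-fold lower number from compound 2 to compound 3 (0.07 log units; within the scatter). For compound 3 the estimated value is 9000 nM, with an expected range of 3500 nM to 20000 nM.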

Compound 3, concentration for 50% growth inhibition: 10800 nM
For compound 3 the middle estimate is 1.2-fold (0.08 log units) below the measured one; measured number inside the range.
By their numbers in this assay, from the lowest: compounds 1, 2 and 3 (each within the scatter of the next).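

Among the compounds shown here, putting 4-chlorophenyl in place of 3-chlorobenzyl on a nitrogen on an aromatic ring gives a 1.0-fold higher number from compound 2 to compound 3 (0.01 log units; within the scatter) in this assay and is the first pair here to isolate this change, which cannot be told apart from the scatter. Hydrogen in place of methyl on a saturated chain carbon bound to two saturated chain carbons gives a 1.1-fold higher number from compound 1 to compound 3 (0.02 log units; within the scatter) and so also stays inside the scatter, now with the 4-chlorophenyl group held fixed. Nothing measured here offers an explanation for either result.

As far as these compounds go, all three compounds carry a chlorine on the aromatic ring attached to that nitrogen, so it remains open whether a methoxy group or a carboxylic acid in its place would move the number beyond the scatter. From the compounds shown here alone, the effect of a much shorter chain, such as methyl, in place of the saturated chains also remains open.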